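The source may hold more compounds than are shown below. What is called first, only, known or untested is meant among the compounds shown, and "the series" means these compounds.

Measured compounds:
compound 1, `COc1cccc(Oc2c(NS(=O)(=O)c3ccc(C(C)(C)C)cc3)ncnc2OCCOc2ccncn2)c1`: 1.2 nM in an assay on cells (Endothelial cell) for binding affinity to Endothelin-1 receptor (Sus scrofa); on this read-out higher numbers stand for weaker inhibition and lower numbers for stronger inhibition
compound 2, `CCc1ccc(-c2c(NS(=O)(=O)c3ccc(C(C)(C)C)cc3)ncnc2OCCOc2ncc(SC)cn2)cc1`: 0.013 nM in this assay

Compound 2 stands lowest of the two numbers; the nearest, compound 1, gives a far higher number, a gap beyond the scatter. Compound 3, `CSc1cnc(OCCOc2ncnc(NS(=O)(=O)c3ccc(C(C)(C)C)cc3)c2-c2ccc(C(C)C)cc2)nc1`, has not been measured. It differs from compound 2 by methyl in place of hydrogen on a saturated chain carbon bound to an aromatic carbon and a saturated chain carbon, a small change at the outer end of one side group. Among the measured compounds shown here, no step between two measured compounds shows what this kind of change does, so the expectation rests on compound 2 alone. The author expects a step of a 1.5-fold higher number from compound 2 to compound 3 (0.19 log units; within the scatter) that stays within the scatter. Compound 3 is therefore estimated at 0.02 nM, between 0.005 nM and 0.08 nM.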

Compound 3, half-maximal inhibitory concentration: 1.2 nM
Compound 3: the middle estimate sits 60-fold (1.78 log units) below what was measured; the whole stated range lies below it.
By their numbers in this assay, from the lowest: compound 2; then compounds 1 and 3 (each within the scatter of the next).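

Going from 4-ethylphenyl to 4-isopropylphenyl gives a 92-fold higher number from compound 2 to compound 3 (1.97 log units; beyond the scatter) in this assay and so shows that this position is far from indifferent to small changes. One added methyl, on a saturated chain carbon bound to an aromatic carbon and a saturated chain carbon, is enough to produce a step beyond the scatter, which compound 2 alone could not show. Nothing available explains this step. Going by these compounds, it remains open whether a propyl chain or a cyclopropyl ring here would read like ethyl or like isopropyl. On these data alone, whether the same methyl has this effect on a different core also remains open.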